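The source may report more compounds than this note shows. Statements on the series, on what has been measured and on what is new or still open speak of the compounds shown alone.

Compound 2 `CC(O)(CSc1ccccc1)c1nc(-c2ccccc2)no1` is the parent of this pair; in a functional assay on DU-145 cells (Homo sapiens) for cytotoxicity, read by MTT assay (on this read-out higher numbers stand for weaker inhibition and lower numbers for stronger inhibition), compound 2 reaches only the limit > 100000 nM, a bound of the assay rather than a number, so the reading for compound 2 is open-ended at the weak end of the range. Within the data shown here, the only neighbour with a value is compound 1 `CC(O)(CSc1ccc(Cl)cc1)c1nc(-c2ccccc2)no1`, which in this assay gives 70700 nM. The step of an at least 1.4-fold higher number from compound 1 to compound 2 (0.15 log units; that floor lies within the scatter) therefore separates the two, although its floor lies within the scatter and is fixed by the limit of > 100000 nM in this assay, at which 1 of the 2 values shown sits, rather than by a measured gap. Compound 3 `CC(O)(CSc1ccc(Br)cc1)c1nc(-c2ccccc2)no1` reverses that move with a heavier halogen: bromo in place of hydrogen on an aromatic carbon. By analogy with the step from compound 1 to compound 2, the bromo analogue is expected to land back near compound 1, a change of an at least 1.3-fold lower number from compound 2 to compound 3 (0.12 log units; that floor lies within the scatter) from the limit of compound 2, with a fair chance that the assay again reports only a limit. Compound 3 is thus estimated at 75000 nM in this assay, within 30000 nM to 200000 nM.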

Compound 3, half-maximal inhibitory concentration: > 100000 nM
Compound 3: no number, only a limit; the forecaster's own chance of this, stated with the estimate: 40%; at least 1.3-fold (0.12 log units) between middle value and limit.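

In this assay, the 4-bromophenyl group of compound 3 does not give a measured value at this position, so chloro remains the only substituent here with a number. Bromo in place of chloro gives an at least 1.4-fold higher number from compound 1 to compound 3 (0.15 log units; that floor lies within the scatter), a floor set by a limit and not by a measured gap, while the step between the other two compounds cannot be read. Comparison at this position is therefore capped at the weak end of the range: the limit of > 100000 nM in this assay, at which 2 of the 3 values shown sit.

The compounds shown leave open whether chloro really differs from bromo or hydrogen on this aromatic carbon, or whether the halogens differ at all. Also open, going by these compounds, is how an amine or a carboxylic acid on the same carbon would read in this assay.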